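The source may hold more compounds than are shown below. What is called first, only, known or untested is meant among the compounds shown, and "the series" means these compounds.

Within the data shown here, compound 3, whose structure is `Cc1cc(N2CC[C@@H](C)[C@@H](N(C)c3ncnc4[nH]ccc34)C2)n2nc(SCc3nc4ccccc4[nH]3)nc2n1`, is one of three compounds measured in a toxicity assay on GES1 cells (Homo sapiens) for inhibition, read by MTT assay, with a stated time of 72 h; a higher number here means a weaker inhibitor, a lower number a stronger inhibitor; compound 3 gives 40200 nM. Compound 1, with structure `Cc1cc(N2CC[C@@H](C)[C@@H](N(C)c3ncnc4[nH]ccc34)C2)n2ncnc2n1`, gives 57900 nM in this assay, and compound 2, with structure `Cc1cc(N2CC[C@@H](C)[C@@H](N(C)c3ncnc4[nH]ccc34)C2)n2nc(SCC3CC3)nc2n1`, gives 27900 nM. The step from compound 1 to compound 2 is a 2.1-fold lower number from compound 1 to compound 2 (0.32 log units; beyond the scatter), whereas the other two steps, a 1.4-fold lower number from compound 1 to compound 3 (0.16 log units; within the scatter) and a 1.4-fold higher number from compound 2 to compound 3 (0.16 log units; within the scatter), are both within the scatter, so compound 3 cannot be ranked against its neighbours with confidence.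

Compound 4, with structure `Cc1cc(N2CC[C@@H](C)[C@@H](N(C)c3ncnc4[nH]ccc34)C2)n2nc(SCc3ccc(F)cc3)nc2n1`, differs from compound 3 in one place: 4-fluorophenyl in place of 1H-benzimidazol-2-yl on a saturated chain carbon bound to a sulfur. Among the measured compounds shown here, the step that bears on this is the one from compound 2 to compound 3, which also exchanged the group on a saturated chain carbon bound to a sulfur and stayed within the scatter. On that basis the expected step of a 1.1-fold lower number from compound 3 to compound 4 (0.05 log units; within the scatter) is none beyond the scatter. Compound 4 is therefore estimated at 36000 nM, with a likely range from 17000 nM to 75000 nM.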

Compound 4, half-maximal inhibitory concentration: 12300 nM
Compound 4: the middle estimate sits 2.9-fold (0.47 log units) above what was measured, and the stated range ends above it.
By their numbers in this assay, from the lowest: compound 4; then compounds 2, 3 and 1 (each within the scatter of the next, the first and the last beyond it).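

In this assay, the group on the saturated chain carbon bound to a sulfur now shifts the number beyond the scatter: 4-fluorophenyl lowers it both in place of 1H-benzimidazol-2-yl (a 3.3-fold lower number from compound 3 to compound 4 (0.51 log units; beyond the scatter)) and in place of cyclopropyl (a 2.3-fold lower number from compound 2 to compound 4 (0.36 log units; beyond the scatter)). Among these compounds, the earlier exchange at this place stayed within the scatter, so this is the first readable sign that the choice of group there matters, and compound 4 has the lowest number of the four. Among the compounds shown here, the whole (4-fluorobenzyl)sulfanyl group in place of hydrogen on an aromatic carbon gives the largest step so far (a 4.7-fold lower number from compound 1 to compound 4 (0.67 log units; beyond the scatter)), but no measurement is available to explain these steps.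

From the compounds shown here alone, it remains open whether the fluorine is needed, as a plain benzyl group would show. Also open, going by these compounds, is how an amine or a carboxylic acid on that chain carbon would read here.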